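The compounds below may be only part of what the source reports. "The series", "measured", "known", "first", "only" and "open" are said of these compounds alone.

Working notes on the series. Compound 1 `COc1cc(-c2ccnc3c(-c4ccc(C)cc4)cnn23)cc(OC)c1OC` in a functional assay on B16-F0 cells (Mus musculus) for inhibition, read by CCK-8 assay, with a stated time of 48 h (a lower number here means a stronger inhibitor, a higher number a weaker inhibitor), returns only a limit of the assay, > 10000 nM. Compound 2 `COc1cc(-c2cc3nccc(-c4c[nH]c5ccccc45)n3n2)cc(OC)c1OC` likewise returns a limit, > 10000 nM. For the measured compounds named here, compound 3 `COc1cc(-c2ccnc3cc(-c4c[nH]c5ccccc45)nn23)cc(OC)c1OC` gives 40 nM, the only finite number in this assay so far. The rest of the set is the limit of > 10000 nM in this assay, at which 2 of the 3 values shown sit. Compound 4 `COc1cc(-c2ccnc3cc(-c4ccc(C(F)(F)F)cc4)nn23)cc(OC)c1OC` differs from compound 3 in one place: 4-(trifluoromethyl)phenyl in place of 1H-indol-3-yl on an aromatic carbon. Going by the values given here, no step between two measured compounds is available to calibrate this change, so the expectation rests on the structures alone. A loss of potency in this assay beyond the usual scatter is expected, with a fair chance that only a limit is returned. Compound 4 is estimated at 1200 nM, range 150 nM to 9000 nM. The expected step from compound 3 to compound 4 is a 30-fold higher number from compound 3 to compound 4 (1.48 log units; beyond the scatter).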

Compound 4, half-maximal inhibitory concentration: 1770 nM
For compound 4 the middle estimate is 1.5-fold (0.17 log units) below the measured one, and the stated range covers the measured number.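

At this aromatic carbon of the five-membered aromatic ring with 2 nitrogen, the group bears strongly on potency in this assay: 4-(trifluoromethyl)phenyl in place of 1H-indol-3-yl gives a 44-fold higher number from compound 3 to compound 4 (1.65 log units; beyond the scatter). The loss is partial, since compound 4 still returns a finite number and not a limit of the assay. Nothing available gives a cause for this step.

As far as these compounds go, whether the loss follows the hydrogen-bond donor or the five-membered aromatic ring of 1H-indol-3-yl stays open, as this change removes both together. Also open, from the compounds shown here alone, is how a phenyl group carrying an amine or a carboxylic acid would read at this carbon in this assay.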